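Replacing 4-methoxyphenyl with 2-hydroxy-3-methoxyphenyl

The compounds below may be only part of what the source reports. "The series", "measured", "known", "first", "only" and "open" are said of these compounds alone.

Compound 1 `CN(C)c1ccc(-c2cc(-c3cccc(NS(C)(=O)=O)c3)nc(N)c2C#N)cc1`: 30 nM
Compound 2 `COc1ccc(-c2cc(-c3cccc(NS(C)(=O)=O)c3)nc(N)c2C#N)cc1`: 130 nM

In a functional assay on cells (Cancer cell lines, Homo sapiens) for antiproliferative activity, read by sulforhodamine B assay, with a stated time of 48 h (on this read-out lower numbers stand for stronger inhibition of growth and higher numbers for weaker inhibition of growth), compound 2, at 130 nM, has the higher of the two numbers. The next step leads to compound 3 `COc1cccc(-c2cc(-c3cccc(NS(C)(=O)=O)c3)nc(N)c2C#N)c1O`, which carries 2-hydroxy-3-methoxyphenyl in place of 4-methoxyphenyl on an aromatic carbon. Within the data shown here, only one measured step bears on this change. That step, a 4.3-fold higher number from compound 1 to compound 2 (0.64 log units; beyond the scatter), exchanges dimethylamino for methoxy and is modest in size. Among the measured compounds shown here, no measured compound carries a hydroxy group or shows the effect of moving the methoxy group, so the direction rests on little evidence. A modest step towards a higher number in this assay is expected, and the estimated change is a 2.3-fold higher number from compound 2 to compound 3 (0.36 log units; beyond the scatter). The estimate for compound 3 is 300 nM, with an expected range from 70 nM to 1500 nM.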

Compound 3, concentration for 50% growth inhibition: 130 nM
Compound 3: middle estimate off by 2.3-fold (0.36 log units), on the high side; measured number inside the range.
By their numbers in this assay, from the lowest: compound 1; then compounds 2 and 3 (each within the scatter of the next).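

In this assay, the position opposite the ring nitrogen takes 2-hydroxy-3-methoxyphenyl in place of 4-methoxyphenyl with no change at the digits printed from compound 2 to compound 3 (within the scatter) as the result, so the added hydroxy group and the different methoxy placement together leave the number where it was. The 4-(dimethylamino)phenyl group remains ahead of this new group as well, with a 4.3-fold higher number from compound 1 to compound 3 (0.64 log units; beyond the scatter) on that exchange, and compound 1 keeps the lowest number of the three. No measurement at hand offers an explanation for either step.

From the compounds shown here alone, what the hydroxy group and the methoxy placement each contribute on their own stays open, since compound 3 carries the two together and their separate effects could cancel. Also open, going by these compounds, is whether a pyrrolidine or a primary amine at the place of the dimethylamino group would keep the number of compound 1.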